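A few compounds are considered here, and "the series" means these few. Any claim that something is new, unique, unknown or untested is made for them only; others in the source may bear on it.

Compound 1 `O=C(NCc1ccc(F)cc1)c1nc(NCCO)c2cccnc2c1O`: "not determined" (no result reported)
Compound 2 `C[C@H](Nc1c(C(=O)NCc2ccc(F)cc2)nc(Br)c2cccnc12)c1ccccc1`: > 20000 nM
Compound 3 `O=CNCCCCCCNc1nc(C(=O)NCc2ccc(F)cc2)c(O)c2ncccc12`: not yet measured

In a functional assay on HCT-116 cells (Homo sapiens) for cytotoxicity, read by MTT assay, with a stated time of 72 h (a lower number here means a stronger inhibitor, a higher number a weaker inhibitor), compound 1 has no number to stand on: its entry reads "not determined" (no result reported). Compound 2 gives > 20000 nM, which is a limit of the assay and not a number. The change to follow is 4-(formylamino)butyl in place of hydroxy on a saturated chain carbon, two bonds along the chain from a nitrogen on an aromatic ring, with 4-(formylamino)butyl in place of hydroxy on a saturated chain carbon, two bonds along the chain from a nitrogen on an aromatic ring. Within the data shown here, no measured step gives its size in this assay, so only a tentative expectation is possible: a sizeable step towards stronger inhibition. Compound 3 is estimated at 3000 nM, with an expected range from 400 nM to 20000 nM.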

Compound 3, half-maximal inhibitory concentration: 6000 nM
For compound 3 the middle estimate is 2.0-fold (0.30 log units) below the measured one; the range from low to high includes it.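

Among these compounds, compound 1 has no result, so no step from it to compound 3 can be read. The compounds shown leave open what 4-(formylamino)butyl in place of hydroxy does to cytotoxicity, and nothing given explains the value of compound 3.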